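The source may report more compounds than this note shows. Statements on the series, on what has been measured and on what is new or still open speak of the compounds shown alone.

Of the compounds shown here, three sharing one core have been measured in an assay on membranes from uterus for displacement of a labelled ligand from Angiotensin type II receptor (Sus scrofa), with a stated time of 1.5 h; a higher number here means a weaker inhibitor, a lower number a stronger inhibitor. Compound 1 `CCCCOC(=O)NS(=O)(=O)c1sc(CC(C)C)cc1-c1ccc(CN2C(=O)CCC2=O)cc1` carries a (2,5-dioxopyrrolidin-1-yl)methyl group on its outer benzene ring. For compound 1 this assay reports only a limit, > 10000 nM, so no number is known for it. Compound 2 `CCCCOC(=O)NS(=O)(=O)c1sc(CC(C)C)cc1-c1ccc(C(=O)c2cccs2)cc1` carries a (thiophen-2-yl)carbonyl group instead and gives 18.8 nM in this assay. Compound 3 `CCCCOC(=O)NS(=O)(=O)c1sc(CC(C)C)cc1-c1ccc(Cc2ncco2)cc1` carries a (1,3-oxazol-2-yl)methyl group and gives 3.9 nM in this assay, the lowest of the two numbers shown; the only other number is separated from it by a 4.8-fold lower number from compound 2 to compound 3 (0.68 log units; beyond the scatter). The two steps up from the limit are an at least 530-fold lower number from compound 1 to compound 2 (2.72 log units; beyond the scatter) and an at least 2500-fold lower number from compound 1 to compound 3 (3.40 log units; beyond the scatter), both resting on that limit.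

Compound 4 `CCCCOC(=O)NS(=O)(=O)c1sc(CC(C)C)cc1-c1ccc(C(=O)c2ncco2)cc1` differs from compound 3 in one place: (1,3-oxazol-2-yl)carbonyl in place of (1,3-oxazol-2-yl)methyl on an aromatic carbon. Among the measured compounds shown here, no measured step changes only the linker while keeping the ring. The closest guide is the step from compound 2 to compound 3, which changed both ring and linker, and the carbonyl-linked compound 2 gave the higher number. A modest rise in the number is therefore expected, near the edge of the scatter. The step from compound 3 to compound 4 is expected to be a 2.6-fold higher number from compound 3 to compound 4 (0.41 log units; beyond the scatter). Compound 4 is estimated at 10 nM, between 3 nM and 40 nM.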

Compound 4, inhibition constant: 13.8 nM
Compound 4: the middle estimate sits 1.4-fold (0.14 log units) below what was measured, and the stated range covers the measured number.
By their numbers in this assay, from the lowest: compound 3; then compounds 4 and 2 (each within the scatter of the next). At a limit, above all of these: compound 1.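

In this assay, the step that changes only the link and keeps the 1,3-oxazol-2-yl ring gives a 3.5-fold higher number from compound 3 to compound 4 (0.55 log units; beyond the scatter), so on this aromatic carbon, para to a large group, the link alone shifts the number beyond the scatter, with the methyl link giving the lower one. Exchanging the ring while keeping the carbonyl link gives a 1.4-fold lower number from compound 2 to compound 4 (0.13 log units; within the scatter), which is within the scatter, so thiophen-2-yl and 1,3-oxazol-2-yl cannot be told apart on a carbonyl carbon, and the earlier gap between the thiophen-2-yl ketone and the oxazolylmethyl compound now looks more like a matter of the link than of the ring. The (1,3-oxazol-2-yl)carbonyl group also stands far from the (2,5-dioxopyrrolidin-1-yl)methyl group, with an at least 720-fold lower number from compound 1 to compound 4 (2.86 log units; beyond the scatter), a step that rests on a limit and not on a number: the limit of > 10000 nM in this assay, at which 1 of the 4 values shown sits.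

From the compounds shown here alone, the effect of the link has been read with one ring only, so it remains open whether a methyl link would lower the number in the same way with a thiophen-2-yl ring. Going by these compounds, it also remains open how this position would respond to a link of another kind, such as an amine, an ether oxygen or a longer carbon chain.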